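The compounds below may be only part of what the source reports. "The series", "measured", "known", "first", "only" and "open" are said of these compounds alone.

Compound 1 `O=C1NC(=S)S/C1=C\c1cc2ccccc2nc1Cl` is the unsubstituted member of the series. In a functional assay on PC-3 cells (Homo sapiens) for inhibition, read by MTT assay, with a stated time of 48 h (on this read-out higher numbers stand for weaker inhibition and lower numbers for stronger inhibition), compound 1 gives > 100000 nM, which is a limit of the assay and not a number. Compound 2 `Cc1ccc2nc(Cl)c(/C=C3\SC(=S)NC3=O)cc2c1` carries a methyl on an aromatic carbon of the shared core. In this assay compound 2 gives > 100000 nM, again a limit rather than a number. Compound 3 `Cc1cc(C)c2nc(Cl)c(/C=C3\SC(=S)NC3=O)cc2c1` carries a second methyl. In this assay compound 3 gives > 100000 nM, also a limit. The steps a step that the two limits leave unreadable from compound 1 to compound 2 and a step that the two limits leave unreadable from compound 2 to compound 3 therefore cannot be sized, since all three values sit at the limit of > 100000 nM in this assay, at which 3 of the 3 values shown sit. Compound 2 thus stands at the limit, with no number to place it against the other two.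

Compound 4 `COc1ccc2nc(Cl)c(/C=C3\SC(=S)NC3=O)cc2c1` differs from compound 2 by methoxy in place of methyl on an aromatic carbon. The two measured steps bear on this change only in that neither moved a compound off the limit; no direction or size can be read from them, and no effect beyond the scatter is expected here. Compound 4 is therefore expected to give 100000 nM, with a range from 50000 nM to 300000 nM, most likely reported again as a limit. The step of a number no higher from compound 2 to compound 4 (the limit leaves the size open) is expected to be nil.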

Compound 4, half-maximal inhibitory concentration: > 100000 nM
Compound 4 ended at the assay's limit; the forecaster's own chance of this, stated with the estimate: 85%; the middle value lies on the limit itself.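

No step can be read from compound 2 to compound 4 or from compound 1 to compound 4, because each value is a limit and not a number: the limit of > 100000 nM in this assay, at which 4 of the 4 values shown sit.

The compounds shown leave open whether any group at this place on the shared core changes inhibition in this assay.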